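This account rests on a few compounds, and the source may have more. Where it says the series, first, only, none or still open, it means among the compounds named here.

For the measured compounds named here, in a functional assay on A549 cells (Homo sapiens) for inhibition, with a stated time of 48 h, tested at 50 uM (on this read-out lower numbers stand for less inhibition of growth and higher numbers for more inhibition of growth at the one concentration tested), three compounds have numbers so far. Compound 1 (`C=C[C@@](C)(/C=C/c1ccc(OC(=O)CCCCC)cc1)CCC=C(C)C`) gives 58% and compound 2 (`COc1ccc(/C=C/[C@@](C)(/C=C/c2ccc(O)cc2)CCC=C(C)C)cc1`) gives 40% while compound 3 (`COc1ccc(/C=C/[C@@](C)(/C=C/c2ccc(O)cc2)CCC=C(C)C)cc1C=O`) gives 32% as its reading. Compound 3 thus stands within the scatter of compound 2 and, beyond the scatter, under compound 1.

The next compound, compound 4 (`COc1ccc(/C=C/[C@@](C)(/C=C/c2ccc(O)cc2)CCC=C(C)C)cc1CO`), keeps everything in compound 3 except one group: it carries hydroxymethyl in place of formyl on an aromatic carbon and this group sits ortho to a methoxy group. Going by the values given here, no measured compound carries hydroxymethyl, so no measured step shows this change directly. Among the compounds with values here, the only measured step at this place puts formyl in place of hydrogen on an aromatic carbon and reads a number 8 percentage points lower from compound 2 to compound 3 (within the scatter) as its size. Going by that small step, compound 4 is expected to show no change beyond the scatter in this assay and to stay close to the level shared by the two compounds that differ at this place. The expected step is a number 3 percentage points higher from compound 3 to compound 4 (within the scatter) at the middle of the estimate. The estimate for compound 4 is 35% within an expected range of 20% to 50% once it is measured.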

Compound 4, percent growth inhibition at one concentration: 41%
Compound 4: middle estimate off by 6 percentage points, on the low side; low and high end bracket the measured number.
By their numbers in this assay, from the lowest: compounds 3, 2 and 4 (each within the scatter of the next); then compound 1.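

In this assay, the exchange of formyl for hydroxymethyl on this aromatic carbon gives a number 9 percentage points higher from compound 3 to compound 4 (within the scatter) and brings in a hydrogen-bond donor that formyl lacks, yet the reading does not leave the scatter. Set against the compound with hydrogen at this place, hydroxymethyl gives a number 1 percentage points higher from compound 2 to compound 4 (within the scatter) and formyl gives a number 8 percentage points lower from compound 2 to compound 3 (within the scatter) so two different groups, ortho to a methoxy group, have now been read here, and neither separates from hydrogen or from the other beyond the scatter. For the compounds shown here, this position therefore tolerates either group without a change that these readings can resolve, and nothing measured so far bears on why that is so.

From the compounds shown here alone, whether an amine, a carboxylic acid or a longer chain such as hydroxyethyl on this aromatic carbon would stay at this level or move beyond the scatter remains open. The readings also come from one concentration only, so any difference among these compounds that such a single reading cannot resolve also stays open.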